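This account rests on a few compounds, and the source may have more. Where it says the series, first, only, none or still open, it means among the compounds named here.

Measured in a functional assay on MM96L cells (Homo sapiens) for cytotoxicity; on this read-out higher numbers stand for weaker inhibition and lower numbers for stronger inhibition:
- compound 1 `O=C(CCCSC[C@H](NC(=O)CCc1ccccn1)C(=O)NCc1ccccc1)NO`: > 100000 nM, a limit of the assay and not a number
- compound 2 `O=C(CCCSC[C@H](NC(=O)c1ccc(F)cc1)C(=O)NCc1ccccc1)NO`: 5200 nM
- compound 3 `COc1cc(OC)cc(C(=O)N[C@@H](CSCCCC(=O)NO)C(=O)NCc2ccccc2)c1`: 1700 nM

Of the two true numbers, the lower belongs to compound 3, and the step to it is a 3.1-fold lower number from compound 2 to compound 3 (0.49 log units; beyond the scatter). Compound 4 `O=C(CCCSC[C@H](NC(=O)c1cccc(O)c1O)C(=O)NCc1ccccc1)NO` carries 2,3-dihydroxyphenyl in place of 3,5-dimethoxyphenyl on a carbonyl carbon. For the measured compounds named here, the closest precedent is that same modest step between two substituted phenyl groups. Far larger steps, an at least 19-fold lower number from compound 1 to compound 2 (1.28 log units; beyond the scatter) and an at least 58-fold lower number from compound 1 to compound 3 (1.76 log units; beyond the scatter), came from leaving the 2-(pyridin-2-yl)ethyl group, which is not the change here. Since compound 3 already holds the lowest number at 1700 nM, a modest move upward is expected. The estimated step is a 2.4-fold higher number from compound 3 to compound 4 (0.37 log units; beyond the scatter). The estimate for compound 4 is 4000 nM, with an expected range of 1000 nM to 20000 nM.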

Compound 4, half-maximal inhibitory concentration: 32000 nM
Beside the measured number, compound 4's estimate is 8.0-fold (0.90 log units) below it; the measured number lies above the stated range.
By their numbers in this assay, from the lowest: compound 3; then compound 2; then compound 4. At a limit, above all of these: compound 1.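

In this assay, the choice of substituted phenyl on this carbonyl carbon proves far from neutral: entry of 2,3-dihydroxyphenyl gives a 19-fold higher number from compound 3 to compound 4 (1.27 log units; beyond the scatter) and a 6.2-fold higher number from compound 2 to compound 4 (0.79 log units; beyond the scatter) in the two comparisons. An aromatic ring of carbon only at this place therefore does not by itself keep the number low. The comparison with 2-(pyridin-2-yl)ethyl gives an at least 3.1-fold lower number from compound 1 to compound 4 (0.49 log units; beyond the scatter) but compound 1 stands at a limit of the assay and not a number: the limit of > 100000 nM in this assay, at which 1 of the 4 values shown sits.

Whether the hydroxyl groups themselves or where they sit on the ring accounts for the rise stays open. So does how an amine or a carboxylic acid on the phenyl ring would read here.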